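Urea to Amide on a Shared Core: Compound 3

The source may report more compounds than this note shows. Statements on the series, on what has been measured and on what is new or still open speak of the compounds shown alone.

Compound 2 `COc1cc(Cl)cc(-c2nn(-c3cccc(NC(=O)Nc4ccc(Cl)c(Cl)c4)c3)cc2-c2ccncc2)c1` was examined in a functional assay on OVCAR-4 cells (Homo sapiens) for inhibition, read by sulforhodamine B assay, with a stated time of 48 h, tested at 0.01 uM (on this read-out higher numbers stand for a weaker effect at the one concentration tested and lower numbers for a stronger effect), where compound 2 gives 93%. That is the lowest of the two numbers recorded so far; the nearest is compound 1 `O=C(Nc1cccc(-n2cc(-c3ccncc3)c(-c3cc(O)cc(Cl)c3)n2)c1)Nc1ccc(Cl)c(Cl)c1`, which in this assay gives 108%. Among the compounds with values here, the single measured step, a number 15 percentage points lower from compound 1 to compound 2 (beyond the scatter), concerns a methyl in place of hydrogen on an oxygen on an aromatic ring. Compound 3 `COc1cc(Cl)cc(-c2nn(-c3cccc(NC(=O)c4cccc(C(F)(F)F)c4)c3)cc2-c2ccncc2)c1` departs from compound 2 at a different place: 3-(trifluoromethyl)phenyl in place of (3,4-dichlorophenyl)amino on a carbonyl carbon. Within the data shown here, no measured step touches the carbonyl carbon or the groups attached to it, so nothing measured bears on this change, and its effect in this assay cannot be read from compound 1 or compound 2. With both measured numbers weak at this concentration, compound 3 is expected to stay in the same region, with a number 2 percentage points higher from compound 2 to compound 3 (within the scatter) expected to be no change beyond the scatter. Compound 3 is therefore estimated at 95%, between 75% and 115%.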

Compound 3, a percentage reported as activity, at one concentration (the size of the read-out at that concentration, not a potency): 106%
Estimate against measurement, compound 3: 11 percentage points below, and the stated range covers the measured number.
By their numbers in this assay, from the lowest: compound 2; then compounds 3 and 1 (each within the scatter of the next).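

The carbonyl carbon, untouched by the earlier step, proves to be a position where a change registers in this assay: replacing (3,4-dichlorophenyl)amino with 3-(trifluoromethyl)phenyl gives a number 13 percentage points higher from compound 2 to compound 3 (beyond the scatter) and so a weaker effect at the one concentration tested. The urea of compound 2 thus becomes an amide in compound 3, with the amide-type nitrogen on the other side of the carbonyl carbon retained and the hydrogen-bond donor of the departing amino group lost. This single step changes both the link and the ring substituents, so it cannot assign the shift to either, and nothing available explains it.

Open, on these data alone, is whether the link or the ring substituents matter more, a question that (3-(trifluoromethyl)phenyl)amino or 3,4-dichlorophenyl on the same carbonyl carbon would address. Also open, as far as these compounds go, is how a morpholine at this place would read.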